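One nitrogen substituent changes: compound 3 to compound 4

The source may hold more compounds than are shown below. What is called first, only, known or untested is meant among the compounds shown, and "the series" means these compounds.

Measured in a functional assay on BaF3 cells (Mus musculus) for inhibition, read by CCK-8 assay, with a stated time of 72 h; a lower number here means a stronger inhibitor of growth, a higher number a weaker inhibitor of growth:
- Compound 1 `COc1ccc(CNc2cc(Oc3ccc(NC(=O)Nc4ccc(C)c(C(F)(F)F)c4)cc3)ncn2)cc1`: 1000 nM
- Compound 2 `Cc1ccc(NC(=O)Nc2ccc(Oc3cc(N)ncn3)cc2)cc1C(F)(F)F`: > 10000 nM (a limit of the assay, not a number)
- Compound 3 `C=CC(=O)Nc1cc(Oc2ccc(NC(=O)Nc3ccc(C)c(C(F)(F)F)c3)cc2)ncn1`: 1940 nM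

Compound 3 stands level with compound 1 within the scatter: a 1.9-fold higher number from compound 1 to compound 3 (0.29 log units; within the scatter). Compound 4 `Cc1ccc(NC(=O)Nc2ccc(Oc3cc(NCCO)ncn3)cc2)cc1C(F)(F)F` carries 2-hydroxyethyl in place of vinylcarbonyl on a nitrogen on an aromatic ring. Two quite different groups on that nitrogen gave much the same result, as that first step shows. Plain hydrogen there did clearly worse: an at least 10-fold higher number from compound 1 to compound 2 (1.00 log units; beyond the scatter), and an at least 5.1-fold lower number from compound 2 to compound 3 (0.71 log units; beyond the scatter). Compound 4 keeps a group on that nitrogen, so it is expected to stay close to compound 3 at 1940 nM. The expected step is a 1.3-fold higher number from compound 3 to compound 4 (0.11 log units; within the scatter), with none beyond the scatter anticipated in this assay. For compound 4 the estimate is 2500 nM, with an expected range of 800 nM to 8000 nM.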

Compound 4, concentration for 50% growth inhibition: > 10000 nM
Compound 4: only a limit was reported (the forecaster's own chance of this, stated with the estimate: 15%); at least 4.0-fold (0.60 log units) between middle value and limit.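

So carrying just any group on this nitrogen is not enough: 2-hydroxyethyl in place of vinylcarbonyl gives an at least 5.1-fold higher number from compound 3 to compound 4 (0.71 log units; beyond the scatter). The same holds against the 4-methoxybenzyl group, with an at least 10-fold higher number from compound 1 to compound 4 (1.00 log units; beyond the scatter). Compound 2 and compound 4 each report only a limit, so the step between them cannot be read: the limit of > 10000 nM in this assay, at which 2 of the 4 values shown sit.

From the compounds shown here alone, whether 2-hydroxyethyl differs at all from plain hydrogen therefore stays open. Also open, going by these compounds, is whether an amine, a carboxylic acid or a longer chain on this nitrogen would match compound 1 and compound 3 or fall away like compound 4.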